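The compounds below may be only part of what the source reports. "The series", "measured", "known", "first", "only" and "open" are said of these compounds alone.

Compound 1, `Clc1cccc(Cl)c1Cc1nnc(Nc2ccc(COCc3ccoc3)cc2)o1`: in an ADME assay on MT2 cells (Homo sapiens) for cytotoxicity, read by MTT assay (a lower number here means that less compound is tolerated, a higher number that more compound is tolerated), compound 1 gives 21000 nM.
Compound 2, `Clc1cccc(Cl)c1Cc1nnc(Nc2ccc(COCc3ccccc3)cc2)o1`: in this assay compound 2 gives 84000 nM.
Compound 3, `O=c1ncccn1SCCc1ccc(Nc2ncc(Cc3c(F)cccc3F)o2)cc1`: in this assay compound 3 gives only a limit, > 100000 nM.

Compound 3 therefore stands at the limit of this assay and not at a number; the two compounds that share a dichlorophenyl part of the core, compound 1 and compound 2, are the only ones with a measured figure. Compound 4, `Fc1cccc(F)c1Cc1cnc(Nc2ccc(CCOc3ccncc3)cc2)o1`, has not yet been tested. It differs from compound 3 in one place: a group of 7 heavy atoms (5 carbon, 1 nitrogen, 1 oxygen; one six-membered aromatic ring with 1 hetero atom) in place of a group of 8 heavy atoms (4 carbon, 2 nitrogen, 1 oxygen, 1 sulfur; one six-membered aromatic ring with 2 hetero atoms), on a saturated chain carbon, two bonds along the chain from an aromatic carbon.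

Among the compounds with values here, only one measured step exists, and it sits elsewhere in the molecule: a 4.0-fold higher number from compound 1 to compound 2 (0.60 log units; beyond the scatter). That step swaps one aromatic ring for another on a chain carbon next to an oxygen, so it bears on the change to compound 4 only loosely, and it says nothing about the exit of a sulfur-bearing group. With no closer guide, the expectation for compound 4 rests on the standing of compound 3 and on (the limit of > 100000 nM in this assay, at which 1 of the 3 values shown sits). The step from compound 3 to compound 4 in this assay is expected to be an at least 1.1-fold lower number from compound 3 to compound 4 (0.04 log units; that floor lies within the scatter), that is, no clear change. Compound 4 is estimated to give 90000 nM in this assay, within 30000 nM to 250000 nM, with a fair chance of again only a limit.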

Compound 4, half-maximal cytotoxic concentration: 11000 nM
Beside the measured number, compound 4's estimate is 8.2-fold (0.91 log units) above it; the measured number lies below the stated range.
By their numbers in this assay, from the lowest: compounds 4 and 1 (each within the scatter of the next); then compound 2. At a limit, above all of these: compound 3.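

Within the data shown here, the group on this saturated chain carbon, two bonds along the chain from an aromatic carbon, clearly matters in this assay: putting (pyridin-4-yl)oxy in place of the sulfur-bearing group gives an at least 9.0-fold lower number from compound 3 to compound 4 (0.95 log units; beyond the scatter), a step beyond the scatter and the first measured one at this position, since the only earlier step concerned a ring swap elsewhere in the molecule. The direction means that less of compound 4 is tolerated, so a change here alone is enough to move a compound from the limit of the assay to a measured figure. The step gives only a minimum size, not an exact one, because compound 3 has a limit and not a number: the limit of > 100000 nM in this assay, at which 1 of the 4 values shown sits.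

The leaving and entering groups differ in both their ring and the atoms that link it to the chain, and the compounds shown do not separate these two changes. As far as these compounds go, how a phenoxy group, an amine or a carboxylic acid on the same chain carbon would stand in this assay remains open.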